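Moving the trifluoromethyl group in a piperazine amide series

This account rests on a few compounds, and the source may have more. Where it says the series, first, only, none or still open, it means among the compounds named here.

Of the compounds shown here, three sharing one core have been measured in an ADME assay on microsomes from liver (Rattus norvegicus) for metabolic stability, read by LC-MS, using NADPH; on this read-out lower numbers stand for a shorter-lived compound and higher numbers for a longer-lived compound. Compound 1 `O=C(NCCCCN1CCN(c2ccc(Cl)cc2)CC1)c1ccc(-c2ccsc2)cc1` gives 0.837 h in this assay, compound 2 `COc1cccc(N2CCN(CCCCNC(=O)c3ccc(-c4ccsc4)cc3)CC2)c1` gives 0.155 h and compound 3 `O=C(NCCCCN1CCN(c2cccc(C(F)(F)F)c2)CC1)c1ccc(-c2ccsc2)cc1` gives 0.282 h, which places compound 3 second of the three. Compound 4 `O=C(NCCCCN1CCN(c2ccc(C(F)(F)F)cc2)CC1)c1ccc(-c2ccsc2)cc1` differs from compound 3 only by 4-(trifluoromethyl)phenyl in place of 3-(trifluoromethyl)phenyl on an amine nitrogen in a ring. The measured steps of a 5.4-fold lower number from compound 1 to compound 2 (0.73 log units; beyond the scatter) and a 3.0-fold lower number from compound 1 to compound 3 (0.47 log units; beyond the scatter) swap whole groups, and the step of a 1.8-fold higher number from compound 2 to compound 3 (0.26 log units; within the scatter) changes one group, so none directly tests shifting a group around the ring. The compound bearing a group in the 4-position, compound 1, shows the highest number, so a modest rise is expected for compound 4, namely a 1.4-fold higher number from compound 3 to compound 4 (0.15 log units; within the scatter) in this assay. Compound 4 is therefore estimated at 0.4 h, within 0.2 h to 0.85 h.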

Compound 4, half-life: > 1 h
Compound 4 ended at the assay's limit; the forecaster's own chance of this, stated with the estimate: 5%; middle value at least 2.5-fold (0.39 log units) away from the limit.
By their numbers in this assay, from the lowest: compounds 2 and 3 (each within the scatter of the next); then compound 1. At a limit, above all of these: compound 4.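

Moving the group from 3-(trifluoromethyl)phenyl to 4-(trifluoromethyl)phenyl keeps the same atoms but joins them differently, and that alone changes the half-life in this assay: an at least 3.5-fold higher number from compound 3 to compound 4 (0.54 log units; beyond the scatter). The same swap gives an at least 6.4-fold higher number from compound 2 to compound 4 (0.80 log units; beyond the scatter), whereas the change from chloro to trifluoromethyl gives an at least 1.1-fold higher number from compound 1 to compound 4 (0.07 log units; that floor lies within the scatter), so these two groups are not separated here. For compound 4, > 1 h is a limit of the assay, not a number.

Going by these compounds, whether a methoxy or chloro group responds to the same shift stays open, for instance in 4-methoxyphenyl or 3-chlorophenyl.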